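The source may report more compounds than this note shows. Statements on the series, on what has been measured and on what is new or still open speak of the compounds shown alone.

Measured compounds in a functional assay on HT-29 cells (Homo sapiens) for cytotoxicity, read by MTT assay, with a stated time of 72 h; on this read-out higher numbers stand for weaker inhibition and lower numbers for stronger inhibition:

compound 1, `COc1cc2c(Oc3ccc(NC(=O)c4cn(-c5ccc(Cl)cc5)cn4)cc3F)ccnc2cc1OCCCN1CCN(C)CC1`: 1350 nM
compound 2, `COc1cc2c(Oc3ccc(NC(=O)/C=C/S(=O)(=O)c4ccccc4F)cc3F)ccnc2cc1OCCCN1CCN(C)CC1`: 150 nM
compound 3, `COc1cc2c(Oc3ccc(NC(=O)/C=C/S(=O)(=O)c4ccccc4OC)cc3F)ccnc2cc1OCCCN1CCN(C)CC1`: 270 nM

Compound 2 gives the lowest number of the three in this assay, but its gap to compound 3 is within the scatter, so the two cannot be ordered; only compound 1 stands clearly apart, with a 9.0-fold lower number from compound 1 to compound 2 (0.95 log units; beyond the scatter). The change from compound 2 to compound 3, a 1.8-fold higher number from compound 2 to compound 3 (0.26 log units; within the scatter), is within the scatter.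

Compound 4, `COc1cc2c(Oc3ccc(NC(=O)/C=C/S(=O)(=O)c4ccccc4F)cc3F)ccnc2cc1OCCCN1CCC(C)CC1`, differs from compound 2 at the chain end:

4-methylpiperidin-1-yl in place of 4-methylpiperazin-1-yl on a saturated chain carbon, three bonds along the chain from an oxygen on an aromatic ring

Neither measured step touches this part of the molecule: the step from compound 1 to compound 2 alters the group on the carbonyl carbon, and the step from compound 2 to compound 3 alters a substituent on an aromatic carbon. Within the data shown here, no measured pair therefore bears on the exchange of 4-methylpiperazin-1-yl for 4-methylpiperidin-1-yl, and the data give no direction for it. With the rest of compound 2 kept, the working expectation is a step of no size beyond the scatter, with a wide range to cover the lack of precedent. For compound 4 the expected step is a 1.3-fold higher number from compound 2 to compound 4 (0.12 log units; within the scatter). Compound 4 is thus estimated at 200 nM, with a range of 80 nM to 600 nM.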

Compound 4, half-maximal inhibitory concentration: 760 nM
Estimate against measurement, compound 4: 3.8-fold (0.58 log units) below; measured number above the stated range.
By their numbers in this assay, from the lowest: compounds 2 and 3 (each within the scatter of the next); then compounds 4 and 1 (each within the scatter of the next).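

The chain end is not a neutral position in this assay: with the rest of compound 2 kept, 4-methylpiperidin-1-yl in place of 4-methylpiperazin-1-yl gives a 5.1-fold higher number from compound 2 to compound 4 (0.70 log units; beyond the scatter) and so moves the number beyond the scatter. Among these compounds, the exchange leaves the ring size and the number of heavy atoms unchanged and replaces only one ring nitrogen with carbon, so even this small change within the 3-(4-methylpiperazin-1-yl)propyl chain registers in this read-out. Nothing at hand accounts for the size or direction of this step.

As far as these compounds go, whether the exchange gives a similar step with the methoxy substituent of compound 3 remains open. Also open, from the compounds shown here alone, is how other chain ends, such as morpholin-4-yl, unsubstituted piperazin-1-yl or a longer chain, would compare with the 4-methylpiperazin-1-yl of compound 2.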